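Aryl amine swap on the cyclopropyl-pyrimidine TBK1 series

The compounds below may be only part of what the source reports. "The series", "measured", "known", "first", "only" and "open" are said of these compounds alone.

Measured compounds:
compound 1 `O=C(NCCCNc1nc(Nc2cccnc2)ncc1C1CC1)C1CCC1` — 13 nM
compound 2 `O=C(NCCCNc1nc(Nc2cncnc2)ncc1C1CC1)C1CCC1` — 3200 nM

Going by the values given here, in an assay on isolated protein for inhibition of serine/threonine-protein kinase TBK1 (Homo sapiens) (a lower number here means a stronger inhibitor, a higher number a weaker inhibitor), compound 2 gives 3200 nM, the highest of the two numbers; the nearest is compound 1, and the step of a 250-fold higher number from compound 1 to compound 2 (2.39 log units; beyond the scatter) is the only measured step. Among the compounds with values here, the unmeasured compound 3 `O=C(NCCCNc1nc(Nc2cnn(C3CC3)c2)ncc1C1CC1)C1CCC1` differs from compound 2 by 1-cyclopropyl-1H-pyrazol-4-yl in place of pyrimidin-5-yl on a nitrogen on an aromatic ring, so the change again sits on the aromatic amine at the same place as the single measured step. Within the data shown here, that step shows this position carries a large effect on this assay, and it is the only step bearing on the present change; it does not involve the pyrazole, so the direction is not fixed by the data. Compound 3 is nonetheless expected to return toward the range of compound 1, a step of a 130-fold lower number from compound 2 to compound 3 (2.11 log units; beyond the scatter), with an estimate of 25 nM and a range of 6 nM to 120 nM for compound 3.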

Compound 3, half-maximal inhibitory concentration: 10 nM
Estimate against measurement, compound 3: 2.5-fold (0.40 log units) above; low and high end bracket the measured number.
By their numbers in this assay, from the lowest: compounds 3 and 1 (each within the scatter of the next); then compound 2.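

In this assay the change to 1-cyclopropyl-1H-pyrazol-4-yl gives a 320-fold lower number from compound 2 to compound 3 (2.51 log units; beyond the scatter) and so shows that the poor result with pyrimidin-5-yl does not extend to every aromatic group with two ring nitrogens on this amine nitrogen. Against pyridin-3-yl, the same group gives a 1.3-fold lower number from compound 1 to compound 3 (0.11 log units; within the scatter) and so shows that this position holds a six-membered and a five-membered aromatic ring at matching levels, the latter also carrying a cyclopropyl ring. No evidence is at hand on what lies behind these differences.

On these data alone, whether the pyrazole ring or its cyclopropyl carries the result remains open, and a comparison with 1H-pyrazol-4-yl or 1-methyl-1H-pyrazol-4-yl on the same core would separate the two. Also open, as far as these compounds go, is whether the same order of these three groups would hold with a different group in place of the cyclopropyl on the shared core.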